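Trifluoromethyl pyrazole change and clearance in the series

This account rests on a few compounds, and the source may have more. Where it says the series, first, only, none or still open, it means among the compounds named here.

Measured in a toxicity assay on microsomes from liver (Homo sapiens) for metabolic stability, read by LC-MS, using NADPH, tested at 1 uM; a higher number here means faster removal of the compound, a lower number slower removal:
- compound 1 `C[C@@H]1CN(c2sc(C3COC3)nc2-c2nc3ccccc3[nH]2)CCN1C(=O)Cn1cnc2cccnc21`: 38 mL.min-1.g-1
- compound 2 `C[C@@H]1CN(c2sc(C(F)(F)F)nc2-c2nc3ccccc3[nH]2)CCN1C(=O)Cn1cnc2cccnc21`: 89 mL.min-1.g-1
- compound 3 `CCOc1ncc(-c2nc(C(F)(F)F)sc2N2CCN(C(=O)Cn3nccc3C)[C@H](C)C2)cn1`: 65 mL.min-1.g-1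

The value of compound 3 lies within the usual scatter of both compound 1 and compound 2, although those two differ from each other by more than the scatter.

Compound 4 `CCOc1ncc(-c2nc(C(F)(F)F)sc2N2CCN(C(=O)Cn3ccc(C(F)(F)F)n3)[C@H](C)C2)cn1` has not yet been measured in this assay. Its difference from compound 3 is 3-(trifluoromethyl)-1H-pyrazol-1-yl in place of 5-methyl-1H-pyrazol-1-yl on a saturated chain carbon bound to a carbonyl carbon. In words, 3-(trifluoromethyl)-1H-pyrazol-1-yl stands in place of 5-methyl-1H-pyrazol-1-yl on a saturated chain carbon bound to a carbonyl carbon.

Within the data shown here, no measured step covers this exact change. The nearest evidence is a 2.3-fold higher number from compound 1 to compound 2 (0.37 log units; beyond the scatter), where trifluoromethyl replaces oxetan-3-yl on an aromatic carbon, a different place and a different group leaving. That single step supports only a weak upward lean. The expected change is a 1.2-fold higher number from compound 3 to compound 4 (0.09 log units; within the scatter), which is not expected to exceed the scatter.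

Compound 4 is estimated at 80 mL.min-1.g-1, with an expected range of 45 mL.min-1.g-1 to 140 mL.min-1.g-1.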

Compound 4, intrinsic clearance in microsomes: 20 mL.min-1.g-1
Estimate against measurement, compound 4: 4.0-fold (0.60 log units) above; measured number below the stated range.
By their numbers in this assay, from the lowest: compounds 4, 1, 3 and 2 (each within the scatter of the next, the first and the last beyond it).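

In this assay, the acyl side chain is not a silent position: 3-(trifluoromethyl)-1H-pyrazol-1-yl in place of 5-methyl-1H-pyrazol-1-yl on a saturated chain carbon bound to a carbonyl carbon gives a 3.3-fold lower number from compound 3 to compound 4 (0.51 log units; beyond the scatter). Trifluoromethyl therefore carries no single direction across the series, since its entry on an aromatic carbon gave a 2.3-fold higher number from compound 1 to compound 2 (0.37 log units; beyond the scatter), so the two steps, which differ in both place and leaving group, cannot be read as one trend. No accompanying measurement bears on the reason for the lower number in compound 4.

The step changes both the pyrazole substituent and its location, and 3-methyl-1H-pyrazol-1-yl on the same chain would help separate the two. From the compounds shown here alone, whether 3-(trifluoromethyl)-1H-pyrazol-1-yl gives a similar step on the core of compound 2 also remains open.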